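Swapping the amine-bearing ring on a pyrazole enone for a dichlorinated one

The source may report more compounds than this note shows. Statements on the series, on what has been measured and on what is new or still open speak of the compounds shown alone.

Measured compounds:
Compound 1 `COc1ccc(-c2cc(/C=C/C(=O)c3ccc(N)cc3)[nH]n2)cc1`: 81%
Compound 2 `COc1cc(-c2cc(/C=C/C(=O)c3ccc(N)cc3)[nH]n2)cc(OC)c1OC`: 76%

Both compounds were tested in a functional assay on PC-3 cells (Homo sapiens) for cytotoxicity, read by sulforhodamine B assay, with a stated time of 48 h, tested at 1 uM; on this read-out higher numbers stand for a weaker effect at the one concentration tested and lower numbers for a stronger effect. Compound 1 gives 81%, and compound 2 gives 76%. Compound 2 has the lower of the two numbers, but the gap to compound 1 lies within the scatter of repeated runs, so the two compounds cannot be told apart on these data; neither can be called the more active.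

Compound 3 `COc1cc(-c2cc(/C=C/C(=O)c3ccc(Cl)c(Cl)c3)[nH]n2)cc(OC)c1OC` has not yet been measured. It differs from compound 2 in one place: 3,4-dichlorophenyl in place of 4-aminophenyl on a carbonyl carbon. For the measured compounds named here, no pair of measured compounds shows this kind of change, so there is nothing here to say how large a step to expect in this assay, or in which direction; a step no larger than the scatter is the plainest expectation. Compound 3 is accordingly expected to give about 70% in this assay, with a range from 45% to 95%. That estimate means a step of a number 6 percentage points lower from compound 2 to compound 3 (within the scatter), expected to fall within the usual scatter.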

Compound 3, a percentage reported as activity, at one concentration (the size of the read-out at that concentration, not a potency): 87%
Compound 3: the middle estimate sits 17 percentage points below what was measured; the range from low to high includes it.
By their numbers in this assay, from the lowest: compounds 2, 1 and 3 (each within the scatter of the next, the first and the last beyond it).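

In this assay, the group on the carbonyl carbon turns out to matter: 3,4-dichlorophenyl in place of 4-aminophenyl gives a number 11 percentage points higher from compound 2 to compound 3 (beyond the scatter), which on this read-out means a weaker effect at the one concentration tested. For the compounds shown here, compound 1 and compound 2 both carry 4-aminophenyl at this place, so they could not show this; the new step is the first sign that a change here can be read beyond the scatter, though only a modest one. Nothing measured here explains why the step occurs.

The swap removes the amine and brings in the chlorines in one move, and the compounds shown leave open which of the two accounts for the step. They also leave open how a single chlorine, a hydroxyl or a carboxylic acid on this ring would read in this assay.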